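A few compounds are considered here, and "the series" means these few. Any claim that something is new, unique, unknown or untested is made for them only; others in the source may bear on it.

Among the compounds with values here, compound 2 `CCC(=O)Nc1cccc(Oc2nc(Nc3ccc(N(CC)CC)cc3)ncc2Cl)c1` stands lowest of the two numbers measured so far: in an assay on isolated protein for inhibition of NUAK family SNF1-like kinase 2 (Homo sapiens), read by ADP-Glo, with a stated time of 60 min, tested at 10 uM, in the presence of a further agent that is not named here (on this read-out lower numbers stand for less inhibition and higher numbers for more inhibition at the one concentration tested (going by the name of the read-out)), compound 2 gives 21.2%, while compound 1 `CCC(=O)Nc1cccc(Oc2nc(Nc3ccc(N4CCC(OC)CC4)cc3)ncc2Cl)c1` gives 53.4%. Within the data shown here, the one step measured, a number 32.2 percentage points lower from compound 1 to compound 2 (beyond the scatter), bears directly on the next change. Compound 3 `CCC(=O)Nc1cccc(Oc2nc(Nc3ccc(N4CCC(C)CC4)cc3)ncc2Cl)c1` differs from compound 2 as follows: 4-methylpiperidin-1-yl in place of diethylamino on an aromatic carbon. This reverses the ring removal of the measured step, so a rise beyond the scatter is expected, a number 23.8 percentage points higher from compound 2 to compound 3 (beyond the scatter), though the ring substituent differs from that of compound 1. Compound 3 is therefore estimated at 45%, with a range from 25% to 65%.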

Compound 3, a percentage reported as inhibition, at one concentration (the size of the read-out at that concentration, not a potency): 24.8%
The estimate for compound 3 lay 20.2 percentage points above the measured number; the measured number lies below the stated range.
By their numbers in this assay, from the lowest: compounds 2 and 3 (each within the scatter of the next); then compound 1.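

In this assay, 4-methylpiperidin-1-yl in place of diethylamino gives a number 3.6 percentage points higher from compound 2 to compound 3 (within the scatter) and so brings no change beyond the scatter: a six-membered ring at this position does not by itself restore the number of compound 1. Methyl in place of methoxy on a saturated ring carbon gives a number 28.6 percentage points lower from compound 1 to compound 3 (beyond the scatter) in this comparison, so among these three compounds the higher number goes with the methoxy group. No measured evidence explains either step.

As far as these compounds go, whether a hydroxyl group, a dimethylamino group or a longer ether on that ring carbon would match methoxy remains open.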